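The source may report more compounds than this note shows. Statements on the series, on what has been measured and on what is new or still open speak of the compounds shown alone.

Measured compounds:

Compound 1, `COc1cc2c(Nc3ccc(Cl)cc3F)ncnc2c(OC)c1OC` — in a functional assay on SGC-7901 cells (Homo sapiens) for antiproliferative activity, read by MTT assay, with a stated time of 72 h (a higher number here means a weaker inhibitor, a lower number a stronger inhibitor), compound 1 gives > 30000 nM, which is a limit of the assay and not a number.

Compound 2, `COc1cc2c(Nc3ccc(Br)c(F)c3)ncnc2c(OC)c1OC` — in this assay compound 2 gives > 30000 nM, again a limit of the assay rather than a number.

Compound 2 therefore stands only at a limit, and the step that the two limits leave unreadable from compound 1 to compound 2 cannot be read, since both of its ends are limits. The unmeasured compound 3, `COc1cc2c(Nc3ccc(F)c(Cl)c3)ncnc2c(OC)c1OC`, differs from compound 2 by 3-chloro-4-fluorophenyl in place of 4-bromo-3-fluorophenyl on a nitrogen on an aromatic ring. Among the measured compounds shown here, no measured step bears readably on this change; all that is known is the limit of > 30000 nM in this assay, at which 2 of the 2 values shown sit, so neither a direction nor a size beyond the scatter can be drawn from the measured pair. Compound 3 is accordingly expected to sit at or near the same limit, estimated at 40000 nM with a range from 8000 nM to 200000 nM. This expectation corresponds to a step that the limit leaves unreadable from compound 2 to compound 3, most likely reported again only as a limit.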

Compound 3, half-maximal inhibitory concentration: 5420 nM
Estimate against measurement, compound 3: 7.4-fold (0.87 log units) above; the whole stated range lies above it.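

In this assay, the group on this nitrogen proves able to shift the result, which the earlier pair could not show: 3-chloro-4-fluorophenyl in place of 4-bromo-3-fluorophenyl gives an at least 5.5-fold lower number from compound 2 to compound 3 (0.74 log units; beyond the scatter). The same group in place of 4-chloro-2-fluorophenyl gives an at least 5.5-fold lower number from compound 1 to compound 3 (0.74 log units; beyond the scatter), so the shared core with these three halogenated phenyl groups does not always stay at the limit, although the step between the other two compounds still cannot be read. Compound 3 alone yields a number rather than a limit of the assay: the limit of > 30000 nM in this assay, at which 2 of the 3 values shown sit.

On these data alone, whether the gain belongs to the chlorine, the fluorine or their arrangement remains open, as each step changes both halogens' identity or placement together. As far as these compounds go, how a plain phenyl, or a phenyl carrying an amine or a carboxylic acid, would stand at this place also remains open.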